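Fluoro for hydrogen: a repeated step in the series

The source may report more compounds than this note shows. Statements on the series, on what has been measured and on what is new or still open speak of the compounds shown alone.

Measured in a functional assay on CHO-K1 cells for antagonist activity at prostaglandin E2 receptor EP1 subtype (Homo sapiens), read by FLIPR; on this read-out lower numbers stand for stronger inhibition and higher numbers for weaker inhibition:
- compound 1 `Cc1cc(C(=O)O)nn1Cc1cc(Br)ccc1OCc1ccccc1` gives 15.1 nM
- compound 2 `Cc1cc(C(=O)O)nn1Cc1cc(Br)ccc1OCc1ccc(F)cc1` gives 11.8 nM
- compound 3 `Cc1cc(C(=O)O)nn1Cc1ccccc1OCc1ccc(Cl)cc1Cl` gives 8.32 nM

Compound 4 `Cc1cc(C(=O)O)nn1Cc1cc(F)ccc1OCc1ccc(Cl)cc1Cl` is not yet measured in this assay.

From compound 1 to compound 2 the change is fluoro in place of hydrogen on an aromatic carbon. The step it made, a 1.3-fold lower number from compound 1 to compound 2 (0.11 log units; within the scatter), lies within the scatter, so no direction can be read from it.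

Compound 3 differs from compound 1 in its core, and the difference between the two cores is not broken down here. Compound 3 gives the lowest of the three numbers, but its gap to compound 2 and to compound 1 is within the scatter, so it cannot be called the most potent.

From compound 3 to compound 4 the change is fluoro in place of hydrogen on an aromatic carbon. This is the same kind of change as from compound 1 to compound 2, not the same: in compound 4 the entering fluoro sits meta to a large group and para to a large group, whereas in compound 2 it sits only para to a large group.

Because the earlier step of a 1.3-fold lower number from compound 1 to compound 2 (0.11 log units; within the scatter) was small, a small step is expected here too, a 1.1-fold lower number from compound 3 to compound 4 (0.05 log units; within the scatter), resting on that single precedent and on the value of compound 3, 8.32 nM. The estimate for compound 4 in this assay is 7.5 nM, expected to fall between 3.5 nM and 16 nM.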

Compound 4, inhibition constant: 20.4 nM
The estimate for compound 4 lay 2.7-fold (0.43 log units) below the measured number, outside the stated range (above it).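

In this assay, fluoro in place of hydrogen on an aromatic carbon gave a 2.5-fold higher number from compound 3 to compound 4 (0.39 log units; beyond the scatter), so on the core of compound 3 this change weakens inhibition, though only modestly. The change does not carry over from one core to the other with the same effect: the same change on two cores in this assay, a 1.3-fold lower number (0.11 log units; within the scatter) from compound 1 to compound 2 and a 2.5-fold higher number (0.39 log units; beyond the scatter) from compound 3 to compound 4, 3.1-fold (0.50 log units) apart, beyond the scatter of two such steps This shows that the small step on the core of compound 1 is a poor guide to the step on the core of compound 3, but it does not show what separates the two cases, as the pairs differ both in the rest of the core and in the place of the entering fluoro, which in compound 4 is meta to a large group and para to a large group, and one pair per core supports no general rule.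

The compounds shown leave open whether fluoro on another carbon of that ring would also raise the number on the core of compound 3, or whether the rise is tied to this one place. They also leave open whether a methoxy group or a nitrile at the place taken by fluoro in compound 4 would move the number in the same direction.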